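The compounds below may be only part of what the source reports. "The series", "measured", "known", "first", "only" and "open" are said of these compounds alone.

In a functional assay on MV4-11 cells (Homo sapiens) for inhibition, read by resazurin assay, with a stated time of 72 h (a higher number here means a weaker inhibitor of growth, a lower number a stronger inhibitor of growth), compound 3 `Cc1csc(-c2cncc(Cl)c2N2CCC3(CCNC3=O)CC2)c1` gives 650 nM. Compound 1 `O=C1NCCC12CCN(c1c(Cl)cncc1-c1ccoc1)CC2` gives 750 nM, and the two stand level, with a 1.2-fold lower number from compound 1 to compound 3 (0.06 log units; within the scatter). Compound 2 `O=Cc1ccc(-c2cncc(Cl)c2N2CCC3(CCNC3=O)CC2)o1` gives 5190 nM, clearly apart from compound 3, with an 8.0-fold lower number from compound 2 to compound 3 (0.90 log units; beyond the scatter).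

Compound 4 `Cc1cc(-c2cncc(Cl)c2N2CCC3(CCNC3=O)CC2)sc1C=O` differs from compound 3 in one place: formyl in place of hydrogen on an aromatic carbon. This is formyl in place of hydrogen on an aromatic carbon, which turns 4-methylthiophen-2-yl into 5-formyl-4-methylthiophen-2-yl. For the measured compounds named here, no measured pair isolates this change. Going by the values given here, the closest evidence is compound 2, the only measured compound bearing a formyl group, which shows a 6.9-fold higher number from compound 1 to compound 2 (0.84 log units; beyond the scatter). That step also changes the ring attachment and carries no methyl group, so it is only an imperfect guide. The swap from furan-3-yl to 4-methylthiophen-2-yl, by contrast, stayed within the scatter. Among the compounds with values here, a rise is therefore expected in this assay, probably somewhat smaller than the one seen for compound 2. The expected step is a 3.8-fold higher number from compound 3 to compound 4 (0.59 log units; beyond the scatter). The estimated value for compound 4 is 2500 nM, within a range of 800 nM to 7000 nM.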

Compound 4, concentration for 50% growth inhibition: 2530 nM
Beside the measured number, compound 4's estimate is 1.0-fold (0.01 log units) below it; the range from low to high includes it.
By their numbers in this assay, from the lowest: compounds 3 and 1 (each within the scatter of the next); then compound 4; then compound 2.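

In this assay, for the compounds shown here, the formyl group on the aromatic carbon next to the ring sulfur raises the number when it is the only change (a 3.9-fold higher number from compound 3 to compound 4 (0.59 log units; beyond the scatter)), which no earlier pair could show. This rise occurs on a ring that also bears a methyl group, so the higher numbers of compound 2 and compound 4 relative to compound 1 are not confined to one ring type (a 3.4-fold higher number from compound 1 to compound 4 (0.53 log units; beyond the scatter)). The two formyl compounds still differ (a 2.1-fold lower number from compound 2 to compound 4 (0.31 log units; beyond the scatter)), so the ring carrying the formyl group also affects the number.

The compounds shown leave open how a hydroxymethyl group, a carboxylic acid or an aminomethyl group would read on this same aromatic carbon. No measurement is available that accounts for the rise.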